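Swapping acetyl for methyl on the E-configured series

The source may report more compounds than this note shows. Statements on the series, on what has been measured and on what is new or still open speak of the compounds shown alone.

In a functional assay on P388 cells (Mus musculus) for inhibition (on this read-out higher numbers stand for weaker inhibition and lower numbers for stronger inhibition), compound 1 (`C(=C\c1ccco1)\c1ccc2ccccc2c1`) gives > 5000 nM, which is a limit of the assay and not a number. Compound 2 (`COc1cc(/C=C/c2cn(C(C)=O)c3ccccc23)cc(OC)c1OC`) gives > 5000 nM, also a limit and not a number. Compound 3 (`COc1cc(/C=C\c2cn(C(C)=O)c3ccccc23)cc(OC)c1OC`) gives 2850 nM. Compound 2 therefore has no measured value, and the readings are dominated by the limit of > 5000 nM in this assay, at which 2 of the 3 values shown sit.

Compound 4 (`COc1cc(/C=C/c2cn(C)c3ccccc23)cc(OC)c1OC`) keeps the double bond drawn E, as in compound 2, and has methyl in place of acetyl on an aromatic nitrogen.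

Within the data shown here, only one measured step is available, and it is an at least 1.7-fold lower number from compound 2 to compound 3 (0.24 log units; that floor lies within the scatter). Among the measured compounds shown here, it goes with the fact that compounds 2 and 3 differ only in the configuration as drawn, so it does not touch the group on the nitrogen, and no measured pair tests that exchange. Its size offers no direct guide to the new step, and the data give no basis for a direction. Compound 2 remains the closest reference, at the limit > 5000 nM, so a reading near that limit is expected for the new compound.

The expected change is a number no higher from compound 2 to compound 4 (the limit leaves the size open), which is not anticipated to exceed the scatter in this assay. For compound 4 the estimated value is 5000 nM, with an expected range of 1500 nM to 15000 nM.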

Compound 4, half-maximal inhibitory concentration: 3090 nM
Compound 4: middle estimate off by 1.6-fold (0.21 log units), on the high side; the range from low to high includes it.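

Among these compounds, this is the only measured step that touches the group on the aromatic nitrogen, since the earlier step changed configuration alone: an at least 1.6-fold lower number from compound 2 to compound 4 (0.20 log units; that floor lies within the scatter). In this assay, compound 4 gives 3090 nM, so with the double bond drawn E, this compound with methyl on the nitrogen has a number, and replacing acetyl with methyl brings no visible loss on this read-out, though a real gain is not established. The size of the step remains unknown because its starting point is not a number: the limit of > 5000 nM in this assay, at which 2 of the 4 values shown sit.

Among the compounds shown here, whether the exchange from acetyl to methyl gives a similar result with the double bond drawn Z remains open, as the data hold no such pair. Also open, from the compounds shown here alone, is how this position responds to other groups, such as ethyl, benzyl or a longer chain carrying an amine or a carboxylic acid, and so whether any reading here can move clearly beyond the scatter.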